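Replacing the Ring Amine on a Nucleoside Core

This account rests on a few compounds, and the source may have more. Where it says the series, first, only, none or still open, it means among the compounds named here.

Compound 1 `CCCCCCNc1nc2c(SCc3ccccc3)ncnc2n1C1O[C@H](CO)[C@@H](O)[C@H]1O`: 3.7 nM
Compound 2 `OC[C@H]1OC(n2c(NC3CCCCC3)nc3c(SCc4ccccc4)ncnc32)[C@H](O)[C@@H]1O`: 0.94 nM

Of the compounds shown here, two have been measured in an assay on cell membranes for binding affinity to Equilibrative nucleoside transporter 1 (Homo sapiens); on this read-out lower numbers stand for stronger inhibition and higher numbers for weaker inhibition. Compound 1 gives 3.7 nM, and compound 2 gives 0.94 nM, which is the lowest number of the two; the step is a 3.9-fold lower number from compound 1 to compound 2 (0.60 log units; beyond the scatter). Compound 3 `OC[C@H]1OC(n2c(N3CCCC3)nc3c(SCc4ccccc4)ncnc32)[C@H](O)[C@@H]1O` has not yet been measured. It differs from compound 2 by pyrrolidin-1-yl in place of cyclohexylamino on an aromatic carbon. Among the measured compounds shown here, no measured step mirrors this change: the one step known, from a hexyl chain to a cyclohexyl ring, kept the hydrogen-bond donor, whereas the change to compound 3 removes it and also shrinks the ring. Because a 3.9-fold lower number from compound 1 to compound 2 (0.60 log units; beyond the scatter) was only modest, a step of comparable size, and most likely toward a higher number, is expected here, about a 5.3-fold higher number from compound 2 to compound 3 (0.73 log units; beyond the scatter). Compound 3 is therefore estimated at 5 nM, with a range from 1 nM to 25 nM.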

Compound 3, inhibition constant: 410 nM
The estimate for compound 3 lay 82-fold (1.91 log units) below the measured number; the measured number lies above the stated range.
By their numbers in this assay, from the lowest: compound 2; then compound 1; then compound 3.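

In this assay, pyrrolidin-1-yl on this aromatic carbon brings a 440-fold higher number from compound 2 to compound 3 (2.64 log units; beyond the scatter) against cyclohexylamino and a 110-fold higher number from compound 1 to compound 3 (2.04 log units; beyond the scatter) against hexylamino, so this position proves far more sensitive than the earlier change of a 3.9-fold lower number from compound 1 to compound 2 (0.60 log units; beyond the scatter) suggested. Compound 1 and compound 2 both keep the hydrogen-bond donor on the group at this position, while compound 3 lacks it and also carries a five-membered ring in place of the six-membered ring of compound 2. Nothing shown here explains why the number rises so sharply.

Going by these compounds, whether the lost donor or the smaller ring counts for more remains open, since both changed together. A piperidin-1-yl group, with a six-membered ring and no donor, or a cyclopentylamino group, with a five-membered ring and the donor, would separate the two.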